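Replacing an arylamino linker with benzyl on a thiazole acetic acid

The compounds below may be only part of what the source reports. "The series", "measured", "known", "first", "only" and "open" are said of these compounds alone.

Compound 1 `COc1ccccc1Nc1nc(-c2ccc(F)cc2)c(CC(=O)O)s1` and compound 2 `O=C(O)Cc1sc(Nc2ccc(Cl)cc2)nc1-c1ccc(F)cc1` were examined in an in vitro functional assay on HEK285-7 cells for antagonist activity at prostaglandin D2 receptor 2 (Homo sapiens), read by BRET and beta-arrestin recruitment; on this read-out lower numbers stand for stronger inhibition and higher numbers for weaker inhibition. In that assay compound 1 gives 2100 nM, and compound 2 gives 1900 nM. The step of a 1.1-fold lower number from compound 1 to compound 2 (0.04 log units; within the scatter), a 4-chlorophenyl in place of a 2-methoxyphenyl on the nitrogen, changed little. Compound 2 therefore stands at the lowest of the two numbers, although its gap to compound 1 is within the scatter.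

Compound 3 `O=C(O)Cc1sc(Cc2ccccc2)nc1-c1ccc(F)cc1` differs from compound 2 by benzyl in place of (4-chlorophenyl)amino on an aromatic carbon. Among the compounds with values here, no measured step bears directly on this change, since the one measured step only exchanged the aryl group on the nitrogen and left the nitrogen itself in place. Within the data shown here, the change here removes the nitrogen linker altogether, which no earlier step tested. He expects a modest weakening, a step of a 2.4-fold higher number from compound 2 to compound 3 (0.37 log units; beyond the scatter), with wide uncertainty. For compound 3 he estimates 4500 nM, within a range from 1000 nM to 20000 nM.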

Compound 3, half-maximal inhibitory concentration: 180 nM
Compound 3: the middle estimate sits 25-fold (1.40 log units) above what was measured, outside the stated range (below it).
By their numbers in this assay, from the lowest: compound 3; then compounds 2 and 1 (each within the scatter of the next).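

In this assay, within the data shown here, the substituent on this aromatic carbon of the thiazole proved far more sensitive than the earlier pair suggested: the one step that kept the nitrogen, a 1.1-fold lower number from compound 1 to compound 2 (0.04 log units; within the scatter), stayed within the scatter, whereas benzyl in place of (4-chlorophenyl)amino gave an 11-fold lower number from compound 2 to compound 3 (1.02 log units; beyond the scatter). So the hydrogen-bond donor and acceptor counted on the nitrogen are not needed for activity at this position, and a carbon-only group is tolerated and gives the lowest number of the three. No measurement here explains the gain.

The step removes the nitrogen and the chlorine together, so their shares in it remain unseparated; a 4-chlorobenzyl group on this carbon would divide them. Also open, going by these compounds, is how an ether oxygen or a longer chain would behave in place of the benzyl methylene.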